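The compounds below may be only part of what the source reports. "The series", "measured", "known", "first", "only" and "open" are said of these compounds alone.

Working notes on the series. In an ADME assay on L929 cells (Mus musculus) for cytotoxicity, read by resazurin assay, with a stated time of 72 h (a lower number here means a stronger inhibitor, a higher number a weaker inhibitor), compound 1 (`O=C(/C=C/c1ccc2c(c1)B(O)OC2)c1ccccc1O`) reads > 10 ug/mL as a limit. Compound 2 (`O=C(/C=C/c1ccc2c(c1)B(O)OC2)c1ccc([N+](=O)[O-])cc1`) reads > 10 ug/mL as a limit too. Compound 3 (`O=C(/C=C/c1ccc2c(c1)B(O)OC2)c1ccc(O)cc1`) reads > 10 ug/mL as a limit as well, so no number is known for it. The change to compound 4 (`Nc1ccc(C(=O)/C=C/c2ccc3c(c2)B(O)OC3)cc1`) is amino in place of hydroxy on an aromatic carbon and the rest of the structure stays the same. The measured steps that bear on it are a step that the two limits leave unreadable from compound 1 to compound 3 and a step that the two limits leave unreadable from compound 2 to compound 3 and neither has a readable size. All the measured compounds sit together (the limit of > 10 ug/mL in this assay, at which 3 of the 3 values shown sit) and the series shows no difference among them. With compound 3 at > 10 ug/mL as a limit, no step beyond the scatter is expected in this assay in either direction. The estimated change is a step that the limit leaves unreadable from compound 3 to compound 4 and a reading that is only a limit is the likely outcome. The expected value for compound 4 is 15 ug/mL (estimated range 7 ug/mL to 40 ug/mL).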

Compound 4, half-maximal inhibitory concentration: > 10 ug/mL
Compound 4: a limit, no number; the forecaster's own chance of this, stated with the estimate: 75%; the middle value does not contradict the limit.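

No step can be read between compound 4 and compound 1, compound 2 or compound 3 in this assay, since all four readings are limits: the limit of > 10 ug/mL in this assay, at which 4 of the 4 values shown sit.

The compounds shown leave open how these four actually compare, and whether any change to the shared core gives a number in this assay.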